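Lengthening the chain on a shared urea core

The source may hold more compounds than are shown below. What is called first, only, known or untested is meant among the compounds shown, and "the series" means these compounds.

Three ureas built on one shared core have been measured in an assay on isolated protein for inhibition of acyl-CoA:cholesterol acyltransferase (Oryctolagus cuniculus); a higher number here means a weaker inhibitor, a lower number a stronger inhibitor. Compound 1 `CC(C)c1cccc(C(C)C)c1NC(=O)Nc1ccccc1` carries a hydrogen where the others carry a chain, and in this assay compound 1 gives 910 nM. Compound 2 `CCc1ccc(NC(=O)Nc2c(C(C)C)cccc2C(C)C)cc1` gives 100 nM, and compound 3 `CCCCCCCc1ccc(NC(=O)Nc2c(C(C)C)cccc2C(C)C)cc1` gives 19 nM. Compound 3 stands lowest of the three: the step of a 48-fold lower number from compound 1 to compound 3 (1.68 log units; beyond the scatter) is large, while a 5.3-fold lower number from compound 2 to compound 3 (0.72 log units; beyond the scatter) and a 9.1-fold lower number from compound 1 to compound 2 (0.96 log units; beyond the scatter) are each modest. Compound 4 `CCCCCCCCCc1ccc(NC(=O)Nc2c(C(C)C)cccc2C(C)C)cc1` extends the chain of compound 3 one stage further: ethyl in place of hydrogen on a saturated chain carbon, seven bonds along the chain from an aromatic carbon. The two steps that bear on this change, a 9.1-fold lower number from compound 1 to compound 2 (0.96 log units; beyond the scatter) and a 5.3-fold lower number from compound 2 to compound 3 (0.72 log units; beyond the scatter), both lowered the number as the chain grew, but the second was smaller than the first, so the gain appears to shrink as the chain gets longer. A further but smaller lowering is therefore expected, roughly a 1.6-fold lower number from compound 3 to compound 4 (0.20 log units; within the scatter). Compound 4 is estimated at 12 nM, with a range from 5 nM to 35 nM.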

Compound 4, half-maximal inhibitory concentration: 9 nM
Compound 4: middle estimate off by 1.3-fold (0.12 log units), on the high side; the measured number falls inside the stated range.
By their numbers in this assay, from the lowest: compound 4; then compound 3; then compound 2; then compound 1.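

Adding ethyl on a saturated chain carbon, seven bonds along the chain from an aromatic carbon, still helps in this assay: the move gives a 2.1-fold lower number from compound 3 to compound 4 (0.32 log units; beyond the scatter) and shows that the number has not stopped falling at this chain length. Seen from the shorter compounds, nonyl brings an 11-fold lower number from compound 2 to compound 4 (1.05 log units; beyond the scatter) and, against the unsubstituted starting point, a 100-fold lower number from compound 1 to compound 4 (2.00 log units; beyond the scatter) with no compound here breaking the order in which the longer chain gives the lower number. Nothing available here addresses why the chain has this effect.

As far as these compounds go, whether the number keeps falling, levels off or rises again with a longer chain, such as dodecyl, remains open. So does whether a chain ending in a carboxylic acid or an amine would keep the number this low.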